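Compound 1 to compound 3: a sulfonyl exchange

The source may report more compounds than this note shows. Statements on the series, on what has been measured and on what is new or still open speak of the compounds shown alone.

Measured in a functional assay on DU-145 cells (Homo sapiens) for inhibition, read by trypan blue exclusion, with a stated time of 96 h; on this read-out lower numbers stand for stronger inhibition of growth and higher numbers for weaker inhibition of growth:
- compound 1 `O=C(O)c1ccc(C(=O)/C(=C\c2ccc(Cl)c([N+](=O)[O-])c2)SCc2ccc(Cl)cc2)cc1`: 1000 nM
- compound 2 `O=C(O)c1ccc(C(=O)/C(=C\c2ccc(Br)c([N+](=O)[O-])c2)SCc2ccc(Cl)cc2)cc1`: < 1000 nM (a limit, not a number)

Among the measured compounds shown here, compound 1, at 1000 nM, holds the only actual number so far. For compound 2 the entry is the limit of < 1000 nM in this assay, at which 1 of the 2 values shown sits.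

Compound 3 `O=C(O)c1ccc(C(=O)/C(=C\c2ccc(Cl)c([N+](=O)[O-])c2)S(=O)(=O)Cc2ccc(Br)cc2)cc1` is not yet measured. It differs from compound 1 on a double-bonded chain carbon bound to a carbonyl carbon and a double-bonded chain carbon: (4-bromobenzyl)sulfonyl in place of (4-chlorobenzyl)sulfanyl on a double-bonded chain carbon bound to a carbonyl carbon and a double-bonded chain carbon.

For the measured compounds named here, the one measured step with any bearing is bromo in place of chloro on an aromatic carbon, a number no higher from compound 1 to compound 2 (the limit leaves the size open). On these data alone, its size stays open. Going by the values given here, no measured step covers the change from sulfanyl to sulfonyl, so no direction can be argued with confidence in this assay. The expected change is a 1.3-fold lower number from compound 1 to compound 3 (0.10 log units; within the scatter), with no step beyond the scatter assumed.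

For compound 3 the estimated value is 800 nM, with an expected range of 150 nM to 4000 nM.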

Compound 3, concentration for 50% growth inhibition: 25000 nM
Beside the measured number, compound 3's estimate is 31-fold (1.49 log units) below it; the whole stated range lies below it.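

In this assay, the place on a double-bonded chain carbon bound to a carbonyl carbon and a double-bonded chain carbon proves sensitive to substitution: (4-bromobenzyl)sulfonyl in place of (4-chlorobenzyl)sulfanyl gives a 25-fold higher number from compound 1 to compound 3 (1.40 log units; beyond the scatter). Among the compounds shown here, this is the first readable step, since the step to compound 2 ends in a limit and cannot be read. Nothing measured here accounts for this weaker inhibition of growth.

On these data alone, the exchange changes sulfanyl to sulfonyl and chloro to bromo together, so the share of each stays open, as does the reading of (4-chlorobenzyl)sulfonyl or (4-bromobenzyl)sulfanyl at this place. Also open, as far as these compounds go, is whether a linked amine here would keep the level of compound 1, or whether a longer chain between the sulfur and the aromatic ring would change it.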